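What a fluoro may do to compound 3

The source may hold more compounds than are shown below. What is called first, only, known or untested is meant among the compounds shown, and "the series" means these compounds.

Values measured so far in an ADME assay on L6 cells (Rattus norvegicus) for cytotoxicity, read by resazurin assay, with a stated time of 72 h (on this read-out lower numbers stand for stronger inhibition and higher numbers for weaker inhibition), are these
compound 1 `OC(c1ccc(Cl)cc1)(c1ccc(C(F)(F)F)cc1)c1cccnc1` gives 56400 nM
compound 2 `OC(c1ccc(Br)cc1)(c1ccc(C(F)(F)F)cc1)c1cccnc1` gives 54700 nM
compound 3 `N#Cc1ccc(C(O)(c2ccc(C(F)(F)F)cc2)c2cccnc2)cc1` gives 76500 nM

Compound 3 cannot be told apart from the other two compounds. The steps that reach it are a 1.4-fold higher number from compound 1 to compound 3 (0.13 log units; within the scatter) and a 1.4-fold higher number from compound 2 to compound 3 (0.15 log units; within the scatter) and the remaining step is a 1.0-fold lower number from compound 1 to compound 2 (0.01 log units; within the scatter) so all three values sit together within the usual scatter of repeated measurements.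

Compound 4 `N#Cc1ccc(C(O)(c2ccc(C(F)(F)F)cc2)c2cccnc2)c(F)c1` differs from compound 3 in one place, described as fluoro in place of hydrogen on an aromatic carbon and the group changes from 4-cyanophenyl to 4-cyano-2-fluorophenyl. In short, compound 4 carries a fluoro where compound 3 carries a hydrogen.

The measured steps only exchange chloro, bromo and cyano on an aromatic carbon. None of them adds a fluoro, so they bear on this change only indirectly. Still, none of the three moved the number beyond the scatter, and compound 3 at 76500 nM is the natural starting point. A small step in no firm direction is therefore expected.

The step expected is a 1.2-fold lower number from compound 3 to compound 4 (0.07 log units; within the scatter) and it would lie within the scatter. For compound 4 the estimated value is 65000 nM with an expected range from 35000 nM to 115000 nM for the measurement.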

Compound 4, half-maximal inhibitory concentration: 56100 nM
Compound 4: middle estimate off by 1.2-fold (0.06 log units), on the high side, and the stated range covers the measured number.
By their numbers in this assay, from the lowest: compounds 2, 4, 1 and 3 (each within the scatter of the next).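

In this assay, a fluoro on an aromatic carbon, ortho to a large group and meta to a cyano group, gives a 1.4-fold lower number from compound 3 to compound 4 (0.13 log units; within the scatter) and so shows that this hydrogen can be exchanged for a fluoro with no change that stands out from the scatter. The complete 4-cyano-2-fluorophenyl group also cannot be told apart from the groups it is compared with, since putting it in place of 4-bromophenyl gives a 1.0-fold higher number from compound 2 to compound 4 (0.01 log units; within the scatter) and putting it in place of 4-chlorophenyl gives a 1.0-fold lower number from compound 1 to compound 4 (0.00 log units; within the scatter) in the same assay. Going by these compounds alone, the earlier steps only exchanged chloro, bromo and cyano on an aromatic carbon, so this is the first sign that a second place on this ring also leaves the number within the scatter, though it rests on a single small group.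

From the compounds shown here alone, whether an amine, a carboxylic acid or a longer chain at this ortho position would leave the number just as unmoved stays open. Nothing at hand explains why all four numbers sit so closely together.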